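Notes on the step from compound 3 to compound 4

A few compounds are considered here, and "the series" means these few. Any claim that something is new, unique, unknown or untested is made for them only; others in the source may bear on it.

In a functional assay on OVCAR-3 cells (Homo sapiens) for antiproliferative activity, read by MTT assay, with a stated time of 24 h (on this read-out higher numbers stand for weaker inhibition and lower numbers for stronger inhibition), three measured compounds share one core and differ in the group on an amine nitrogen. Compound 1 `Cc1cccc(NNC(=O)c2cccc(NS(=O)(=O)c3cnc(O)nc3O)c2)c1` reads > 20000 nM, which is a limit. Compound 2 `O=C(NNc1ccccc1Cl)c1cccc(NS(=O)(=O)c2cnc(O)nc2O)c1` gives a number, 3350 nM. Compound 3 `O=C(NNc1ccc(F)cc1)c1cccc(NS(=O)(=O)c2cnc(O)nc2O)c1` reads > 20000 nM, again only a limit. Compound 3 therefore sits at the limit of > 20000 nM in this assay, at which 2 of the 3 values shown sit.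

The change to compound 4 `O=C(NNC(=O)c1cccc(NS(=O)(=O)c2cnc(O)nc2O)c1)c1cccc(Cl)c1` is (3-chlorophenyl)carbonyl in place of 4-fluorophenyl on an amine nitrogen. In words, (3-chlorophenyl)carbonyl comes in place of 4-fluorophenyl on an amine nitrogen.

The closest guides are an at least 5.9-fold higher number from compound 2 to compound 3 (0.77 log units; beyond the scatter) and an at least 5.9-fold lower number from compound 1 to compound 2 (0.77 log units; beyond the scatter), both beyond the scatter, while a step that the two limits leave unreadable from compound 1 to compound 3 cannot be read. None of these steps introduces a carbonyl, so they bear on the change only loosely. Only compound 2, with its 2-chlorophenyl group, reaches a number, at 3350 nM.

A modest move toward lower numbers in this assay is expected, although another limit remains quite possible. The expected step is an at least 2.0-fold lower number from compound 3 to compound 4 (0.30 log units; that floor lies within the scatter). Compound 4 is estimated at 10000 nM, with an expected range of 2500 nM to 35000 nM.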

Compound 4, half-maximal inhibitory concentration: 13500 nM
Beside the measured number, compound 4's estimate is 1.4-fold (0.13 log units) below it; the range from low to high includes it.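

In this assay, (3-chlorophenyl)carbonyl on this amine nitrogen gives a number rather than a limit, so a readable value is no longer confined to compound 2, and the limit stays with the other two compounds: the limit of > 20000 nM in this assay, at which 2 of the 4 values shown sit. The steps against those limits are an at least 1.4-fold lower number from compound 3 to compound 4 (0.17 log units; that floor lies within the scatter) and an at least 1.4-fold lower number from compound 1 to compound 4 (0.17 log units; that floor lies within the scatter), and they fix only floors, not sizes. The number that compound 2 gives stays the lower one, with a 4.0-fold higher number from compound 2 to compound 4 (0.61 log units; beyond the scatter), so the new group does not match 2-chlorophenyl at this position.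

The compounds shown do not separate the part played by the carbonyl from that of the chlorine. Going by these compounds, how a plain 3-chlorophenyl group, or an acetyl group without any ring, would read on this nitrogen remains open.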